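Phenyl for methyl on the core of compound 2

The compounds below may be only part of what the source reports. "The series", "measured", "known", "first", "only" and "open" are said of these compounds alone.

Measured so far:
compound 1 `Cc1cc2c(c(N)nn2C)c(N2CCCCC2)n1`: 4%
compound 2 `COCCNc1nc(C)cc2c1c(N)nn2C`: -2%

In an assay on isolated protein for inhibition of serine/threonine-protein kinase Chk2 (Homo sapiens), read by mobility shift assay, tested at 30 uM (a higher number here means more inhibition at the concentration tested (going by the name of the read-out), a lower number less inhibition), compound 2 gives -2%, the lowest of the two numbers; compound 1 is the nearest, and the step of a number 6 percentage points lower from compound 1 to compound 2 (within the scatter) lies within the scatter. Compound 3 `COCCNc1nc(-c2ccccc2)cc2c1c(N)nn2C` is not yet measured. It differs from compound 2 in one place: phenyl in place of methyl on an aromatic carbon. No measured step concerns this change; the only step shown, a number 6 percentage points lower from compound 1 to compound 2 (within the scatter), exchanged a different group on another carbon and stayed within the scatter. Without a guide, the step is expected to be small, a number 8 percentage points higher from compound 2 to compound 3 (within the scatter), in either direction or none beyond the scatter. Compound 3 is therefore estimated at 6%, between -10% and 28%.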

Compound 3, a percentage reported as inhibition, at one concentration (the size of the read-out at that concentration, not a potency): 8%
Estimate against measurement, compound 3: 2 percentage points below; low and high end bracket the measured number.
By their numbers in this assay, from the lowest: compounds 2, 1 and 3 (each within the scatter of the next).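

Phenyl in place of methyl on the aromatic carbon next to the ring nitrogen gives a number 10 percentage points higher from compound 2 to compound 3 (within the scatter) in this assay. This is the first change shown at this position, and even with a whole aromatic ring entering for a methyl, the number does not leave the scatter, so neither a gain nor a loss can be assigned to it. Nothing measured here bears on a cause for this result. From the compounds shown here alone, whether a pyridyl ring or a carboxylic acid on this carbon would move the number beyond the scatter stays open. So does whether a piperidin-1-yl group alongside the phenyl would do so.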